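Aryl group swaps on a shared core: notes toward compound 3

The source may report more compounds than this note shows. Statements on the series, on what has been measured and on what is new or still open speak of the compounds shown alone.

Of the compounds shown here, two have numbers so far. Compound 1 `CCC1=C(O)c2c(oc(-c3ccccc3F)cc2=O)C(CC)(CC)C1=O` sits only at a limit in a functional assay on KB cells (Homo sapiens) for antiproliferative activity, read by sulforhodamine B assay, with a stated time of 3 days; on this read-out lower numbers stand for an effect already at smaller amounts and higher numbers for an effect only at larger amounts of compound: compound 1 gives > 56.2 uM, which is a limit of the assay and not a number. Compound 2 `CCC1=C(O)c2c(oc(-c3ccc(C)c(Cl)c3)cc2=O)C(CC)(CC)C1=O` gives 39 uM in this assay. Between them lies the one measured step, an at least 1.4-fold lower number from compound 1 to compound 2 (0.15 log units; that floor lies within the scatter); its floor is set by the limit of > 56.2 uM in this assay, at which 1 of the 2 values shown sits. Going by the values given here, compound 2 therefore stands as the only compound with a number in this assay; the other value shown is a limit.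

Compound 3 `CCC1=C(O)c2c(oc(-c3cc(C)ccc3C)cc2=O)C(CC)(CC)C1=O` changes the aryl group again: 2,5-dimethylphenyl in place of 3-chloro-4-methylphenyl on an aromatic carbon. Among the compounds with values here, the only step that bears on it is the one from compound 1 to compound 2, which also swaps one aryl group for another and reaches no more than the scatter at its floor. No basis exists for expecting a step beyond the scatter in either direction in this assay.

Compound 3 is therefore expected at about 45 uM, between 20 uM and 120 uM. The expected step for compound 3 is a 1.2-fold higher number from compound 2 to compound 3 (0.06 log units; within the scatter), which is within the scatter.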

Compound 3, concentration for half-maximal effect: 14.5 uM
The estimate for compound 3 lay 3.1-fold (0.49 log units) above the measured number, and the stated range ends above it.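

In this assay this position now shows that a swap of one aryl group for another can move the number beyond the scatter: a 2.7-fold lower number from compound 2 to compound 3 (0.43 log units; beyond the scatter). The 3-chloro-4-methylphenyl and 2,5-dimethylphenyl groups both have one six-membered aromatic ring of carbon only, no hydrogen-bond donors or acceptors and no net charge, so the step arises with those counts unchanged, and compound 3 is the most active of the compounds shown. The change from 2-fluorophenyl to 2,5-dimethylphenyl also goes beyond the scatter, an at least 3.8-fold lower number from compound 1 to compound 3 (0.58 log units; beyond the scatter), but its size is only a floor, as compound 1 gives a limit and not a number: the limit of > 56.2 uM in this assay, at which 1 of the 3 values shown sits.

The compounds shown do not separate the loss of chlorine from the different placing of the methyl groups, since compound 2 and compound 3 differ in both at once, so neither can be credited with the step. Also open, going by these compounds, is how the number would respond to an aryl group carrying an amine or a carboxylic acid, or to an ethyl or longer chain in place of a methyl group on the ring.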